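Working notes: from compound 2 to its hydroxyl-bearing chain

A few compounds are considered here, and "the series" means these few. Any claim that something is new, unique, unknown or untested is made for them only; others in the source may bear on it.

Of the compounds shown here, two have numbers so far, compound 1 (`C=CCc1ccc(OCc2cn(-c3cccc([N+](=O)[O-])c3)nn2)c(O)c1`) and compound 2 (`C=CCc1cc(O)c(O)c(CN2CCC(C)CC2)c1`). In a functional assay on HepG2 cells (Homo sapiens) for inhibition, read by MTT assay, with a stated time of 72 h, tested at 50 uM (on this read-out higher numbers stand for more inhibition of growth at the one concentration tested and lower numbers for less inhibition of growth), compound 1 gives 30.2% while compound 2 gives 69.7% and so holds the higher of the two numbers, with the gap beyond the scatter. These two compounds differ in more than one place, so the gap says nothing about any single change.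

Compound 3 (`C=CCc1cc(O)c(O)c(CN2CCC(CCO)CC2)c1`) differs from compound 2 in one place (hydroxymethyl in place of hydrogen on a saturated chain carbon bound to a saturated ring carbon), on a saturated chain carbon bound to a saturated ring carbon. The same difference reads methyl to 2-hydroxyethyl. For the measured compounds named here, no measured pair shows this change, so the only anchor is compound 2 at 69.7% and the expectation stays loose. In this assay a moderate fall is expected, the estimated step being a number 12.7 percentage points lower from compound 2 to compound 3 (beyond the scatter) and no more. Compound 3 is expected at 57% (estimated range 37% to 76%).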

Compound 3, percent growth inhibition at one concentration: 2%
Beside the measured number, compound 3's estimate is 55 percentage points above it, and the stated range ends above it.
By their numbers in this assay, from the lowest: compound 3; then compound 1; then compound 2.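

The position on the saturated chain carbon bound to a saturated ring carbon is not indifferent to what it carries: in this assay the change of methyl to 2-hydroxyethyl gives a number 67.7 percentage points lower from compound 2 to compound 3 (beyond the scatter) and leaves almost no growth inhibition at the one concentration tested. For the compounds shown here, this is the first step that can be read at a single place, which the gap between compound 1 and compound 2 could not offer. Nothing available bears on the reason for this step.

The compounds shown leave open whether the fall goes with the hydroxyl itself or with the longer chain. An ethyl, a 2-methoxyethyl or a 2-aminoethyl group at this place would separate those two readings.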